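Replacing propylamino with methyl

The source may hold more compounds than are shown below. What is called first, only, known or untested is meant among the compounds shown, and "the series" means these compounds.

compound 1 `CCOC(=O)C(=O)Nc1ccc(N(C)C)cc1C#N` gives 1 mg/kg
compound 2 `CCCNc1cccc(NC(=O)C(=O)OCC)c1C#N` gives 0.5 mg/kg
compound 3 `CCOC(=O)C(=O)Nc1cccc(C)c1C#N` is not yet measured

In a functional assay on the whole organism with Rattus norvegicus as the target (a higher number here means that more compound is needed for the effect, a lower number that less compound is needed), compound 2 gives 0.5 mg/kg and compound 1 gives 1 mg/kg and the two lie within the scatter of each other. For the measured compounds named here, compound 3 carries methyl in place of propylamino on an aromatic carbon, ortho to a cyano group methyl in place of propylamino on an aromatic carbon and no measured pair shows what this exchange does. A modest rise in the number is therefore expected, and the estimated change is a 3.0-fold higher number from compound 2 to compound 3 (0.48 log units; beyond the scatter) with considerable uncertainty. The estimate for compound 3 is 1.5 mg/kg with an expected range from 0.3 mg/kg to 8 mg/kg.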

Compound 3, dose for half-maximal effect: 5.3 mg/kg
Compound 3: the middle estimate sits 3.5-fold (0.55 log units) below what was measured; the range from low to high includes it.
By their numbers in this assay, from the lowest: compounds 2 and 1 (each within the scatter of the next); then compound 3.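

In this assay, methyl in place of propylamino on an aromatic carbon, ortho to a cyano group, gives an 11-fold higher number from compound 2 to compound 3 (1.03 log units; beyond the scatter), a large step showing that the number is sensitive to the group at this position. The exchange removes the nitrogen and shortens the group, and this single pair cannot separate those two differences. Nothing available explains the rise in the number.

Open, as far as these compounds go, is whether methylamino, which keeps the nitrogen on a short group, or propyl, which keeps the chain without the nitrogen, would stay close to compound 2 or to compound 3.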